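The compounds below may be only part of what the source reports. "The series", "measured", "known", "first", "only" and "open" are said of these compounds alone.

Three measured compounds share one core and differ only in the aryl group attached through the linker: compound 1 `C=C1C[C@]23C[C@@]1(O)CC[C@H]2c1ccc(O)c(C)c1[C@@H]3Cn1cc(-c2ccc(Br)cc2)nn1`, compound 2 `C=C1C[C@]23C[C@@]1(O)CC[C@H]2c1ccc(O)c(C)c1[C@@H]3Cn1cc(-c2ccccc2)nn1` and compound 3 `C=C1C[C@]23C[C@@]1(O)CC[C@H]2c1ccc(O)c(C)c1[C@@H]3Cn1cc(-c2ccc(C)cc2)nn1`. In a functional assay on HL-60 cells (Homo sapiens) for cytotoxicity, read by MTT assay, with a stated time of 4 days (a lower number here means a stronger inhibitor, a higher number a weaker inhibitor), compound 1 gives > 20000 nM, which is a limit of the assay and not a number. In this assay compound 2 gives > 20000 nM, again only a limit. In this assay compound 3 gives > 20000 nM, likewise a limit. The change from compound 2 to compound 1 is bromo in place of hydrogen on an aromatic carbon and its step is a step that the two limits leave unreadable from compound 2 to compound 1; the change between their cores from compound 2 to compound 3 is methyl in place of hydrogen on an aromatic carbon with the step that the two limits leave unreadable from compound 2 to compound 3, and the step that the two limits leave unreadable from compound 1 to compound 3 is equally unreadable, because of the limit of > 20000 nM in this assay, at which 3 of the 3 values shown sit.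

Compound 4 `C=C1C[C@]23C[C@@]1(O)CC[C@H]2c1cc(Br)c(O)c(C)c1[C@@H]3Cn1cc(-c2ccc(C)cc2)nn1` is not yet measured; it differs from compound 3 by bromo in place of hydrogen on an aromatic carbon. Among the compounds with values here, this is the same kind of change as the one from compound 2 to compound 1, but not the same: in compound 1 the bromo sits para to a large group on a six-membered aromatic ring of carbon only, whereas in compound 4 it sits on a ring that is part of a fused or bridged system of four rings, ortho to a hydroxy group and meta to a methyl group. Since the three measured compounds all sit at a limit and the bromo step from compound 2 to compound 1 could not be read, the step from compound 3 to compound 4 in this assay is expected to be a step that the limit leaves unreadable from compound 3 to compound 4, with no measured basis to expect a gain. Compound 4 is therefore estimated at 25000 nM, most likely reported again as a limit, within a range from 8000 nM to 80000 nM.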

Compound 4, half-maximal inhibitory concentration: > 20000 nM
Compound 4: only a limit was reported; the forecaster's own chance of this, stated with the estimate: 70%; the middle value does not contradict the limit.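

In this assay compound 4 gives > 20000 nM, which is a limit of the assay and not a number. No size can be read for the bromo change from compound 3 to compound 4, because the result sits where all the others do: the limit of > 20000 nM in this assay, at which 4 of the 4 values shown sit. The compounds shown leave open whether bromo or methyl in place of hydrogen changes the activity of the shared core in this assay at all.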